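Chain Lengthening on a Thienopyrimidinone Series: Predicting Compound 4

The source may report more compounds than this note shows. Statements on the series, on what has been measured and on what is new or still open speak of the compounds shown alone.

Three close relatives share one core and were tested in an ADME assay on HeLa cells (Homo sapiens) for inhibition, read by MTT assay; a higher number here means a weaker inhibitor of growth, a lower number a stronger inhibitor of growth. Compound 1 `CCCCCc1cc2c(=O)n(CCCSc3nc(-c4cc(OC)c(OC)c(OC)c4)c(C#N)c(=O)[nH]3)cnc2s1` gives 75.8 ug/mL. Compound 2 `CCCCCCc1cc2c(=O)n(CCCSc3nc(-c4cc(OC)c(OC)c(OC)c4)c(C#N)c(=O)[nH]3)cnc2s1` gives 67 ug/mL, and compound 3 `CCCCCCCc1cc2c(=O)n(CCSc3nc(-c4cc(OC)c(OC)c(OC)c4)c(C#N)c(=O)[nH]3)cnc2s1` gives 75.4 ug/mL; all three numbers sit together, each within the scatter of the others, so none stands apart. Within the data shown here, the single measured step, a 1.1-fold lower number from compound 1 to compound 2 (0.05 log units; within the scatter), comes from the same kind of change as the one now in question, cut one bond earlier. Compound 4 `CCCCCCCc1cc2c(=O)n(CCCSc3nc(-c4cc(OC)c(OC)c(OC)c4)c(C#N)c(=O)[nH]3)cnc2s1` differs from compound 2 by methyl in place of hydrogen on a saturated chain carbon, six bonds along the chain from an aromatic carbon. Given that step, no shift beyond the scatter is expected in this assay. Compound 4 is therefore estimated at 65 ug/mL, with a likely range from 35 ug/mL to 130 ug/mL, an expected step of a 1.0-fold lower number from compound 2 to compound 4 (0.01 log units; within the scatter).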

Compound 4, concentration for 50% growth inhibition: 76.1 ug/mL
Compound 4: middle estimate off by 1.2-fold (0.07 log units), on the low side; measured number inside the range.
By their numbers in this assay, from the lowest: compounds 2, 3, 1 and 4 (each within the scatter of the next).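

Adding methyl on a saturated chain carbon, six bonds along the chain from an aromatic carbon, gives a 1.1-fold higher number from compound 2 to compound 4 (0.06 log units; within the scatter) in this assay and adding ethyl five bonds along gives a 1.0-fold higher number from compound 1 to compound 4 (0.00 log units; within the scatter) in the same test. Among these compounds, the one earlier step covered only a single methyl further in, whereas these show that neither the farther position nor the larger ethyl change moves the number beyond the scatter. Nothing available explains this flat response. As far as these compounds go, whether a much longer chain, an amine or a carboxylic acid in place of this methyl would shift the number stays open.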